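Compound 2 and its 4-methoxyphenyl counterpart

This account rests on a few compounds, and the source may have more. Where it says the series, first, only, none or still open, it means among the compounds named here.

Of the compounds shown here, two have numbers so far. In a functional assay on K562 cells (Homo sapiens) for cytotoxicity, read by trypan blue exclusion, with a stated time of 96 h (a lower number here means a stronger inhibitor, a higher number a weaker inhibitor), compound 1 `COC(=O)[C@H](C)Nc1cc(CS(=O)(=O)/C=C/c2c(OC)cc(OC)cc2OC)ccc1OC` gives 200 nM, and compound 2 `COc1cc(OC)c(/C=C/S(=O)(=O)Cc2ccc(OC)c(NC(C(=O)O)c3ccccc3)c2)c(OC)c1` gives 15 nM, the lower of the two numbers.

Compound 3 `COc1ccc(C(Nc2cc(CS(=O)(=O)/C=C/c3c(OC)cc(OC)cc3OC)ccc2OC)C(=O)O)cc1` keeps everything in compound 2 except the phenyl on the carbon bearing the carboxy group, which becomes 4-methoxyphenyl. The change is methoxy in place of hydrogen on an aromatic carbon, para to a large group.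

Within the data shown here, only one measured step bears on this, and only indirectly. The large step of a 13-fold lower number from compound 1 to compound 2 (1.12 log units; beyond the scatter) lies beyond the scatter and shows that the group on the nitrogen can matter in this assay. That step exchanges 1-(methoxycarbonyl)ethyl for carboxy(phenyl)methyl as a whole, however. Among the measured compounds shown here, no measured pair isolates a substituent on the phenyl, so neither size nor direction is established for the new methoxy. A small change is therefore expected, with a 1.3-fold higher number from compound 2 to compound 3 (0.12 log units; within the scatter) estimated to stay within the scatter. For compound 3 the expected value is 20 nM, with an estimated range of 6 nM to 70 nM.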

Compound 3, half-maximal inhibitory concentration: 15 nM
For compound 3 the middle estimate is 1.3-fold (0.12 log units) above the measured one; the range from low to high includes it.
By their numbers in this assay, from the lowest: compounds 2 and 3 (each within the scatter of the next); then compound 1.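

In this assay, among these compounds, the first pair that isolates a substituent on this aromatic ring shows that methoxy in place of hydrogen, para to a large group, gives no change at the digits printed from compound 2 to compound 3 (within the scatter), so phenyl and 4-methoxyphenyl cannot be told apart here. The large gap to the 1-(methoxycarbonyl)ethyl compound also holds with the substituted ring, at a 13-fold lower number from compound 1 to compound 3 (1.12 log units; beyond the scatter), so it is not confined to the unsubstituted phenyl of compound 2. No measurement available here gives a reason for either step.

As far as these compounds go, whether the same place accepts groups other than methoxy remains open, since one substituent says nothing about an amine, a carboxylic acid or a longer chain such as butoxy. The large step also exchanges the ester for the carboxy group and the methyl for an aromatic ring at once, so the contribution of each stays unresolved; a carboxy(methyl)methyl group or a methyl ester of the carboxy(phenyl)methyl group on the same nitrogen would separate them.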